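The source may hold more compounds than are shown below. What is called first, only, known or untested is meant among the compounds shown, and "the series" means these compounds.

In a functional assay on DU-145 cells (Homo sapiens) for inhibition, read by trypan blue exclusion, with a stated time of 72 h (on this read-out higher numbers stand for weaker inhibition and lower numbers for stronger inhibition), compound 2 `O=c1c(S(=O)(=O)c2ccc(F)cc2F)cc2cnc(Nc3ccc4[nH]ccc4c3)nc2n1C1CCCCC1` gives 10000 nM, the highest of the two numbers seen; the nearest is compound 1 `O=c1c(S(=O)(=O)c2ccc(F)cc2F)cc2cnc(Nc3ccc4[nH]ccc4c3)nc2n1C1CC1`, which gives 500 nM. Among the measured compounds shown here, the single measured step here, a 20-fold higher number from compound 1 to compound 2 (1.30 log units; beyond the scatter), is large. Compound 3 `O=c1c(S(=O)(=O)c2ccc(F)cc2F)cc2cnc(Nc3ccc4[nH]ccc4c3)nc2n1C1CCCC1` differs from compound 2 by cyclopentyl in place of cyclohexyl on an aromatic nitrogen. For the measured compounds named here, because the only guide is a 20-fold higher number from compound 1 to compound 2 (1.30 log units; beyond the scatter), and cyclopentyl lies between cyclopropyl and cyclohexyl in ring size, a lower number than compound 2 is expected, though smaller than that step. Compound 3 is thus expected to show a 3.3-fold lower number from compound 2 to compound 3 (0.52 log units; beyond the scatter), an estimate of 3000 nM with a range from 800 nM to 10000 nM.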

Compound 3, half-maximal inhibitory concentration: 5000 nM
Beside the measured number, compound 3's estimate is 1.7-fold (0.22 log units) below it, within the range that was stated.
By their numbers in this assay, from the lowest: compound 1; then compounds 3 and 2 (each within the scatter of the next).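

In this assay, a 2.0-fold lower number from compound 2 to compound 3 (0.30 log units; within the scatter) leaves cyclopentyl and cyclohexyl on this aromatic nitrogen not told apart. By contrast, a 10-fold higher number from compound 1 to compound 3 (1.00 log units; beyond the scatter) shows that the gap from cyclopropyl is already present with cyclopentyl, so compound 1 stands apart from both larger rings. Nothing at hand gives a cause for this.

From the compounds shown here alone, whether cyclobutyl would stay close to cyclopropyl or join the larger rings remains open. So does how an open chain such as isopropyl, or a ring carrying an amine, would read at this position.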